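Hydrogen for hydroxy on the chain of compound 2

This account rests on a few compounds, and the source may have more. Where it says the series, first, only, none or still open, it means among the compounds named here.

- compound 1 `CCCCC[C@H](CCC[C@@H]1CC=CC(=O)O1)OC` at 20500 nM
- compound 2 `CCCCC[C@@H](C[C@H](O)C[C@H]1CC=CC(=O)O1)OC` at 48000 nM
- compound 3 `CCCCC[C@@H](CCC[C@H]1CC=CC(=O)O1)OC` not yet measured

In a functional assay on A2780 ADR cells (Homo sapiens) for cytotoxicity, read by MTT assay, with a stated time of 24 h (on this read-out lower numbers stand for stronger inhibition and higher numbers for weaker inhibition), compound 2 stands at 48000 nM as the higher of the two numbers, and compound 1 stands at 20500 nM. The gap between these two numbers lies beyond the scatter. Compound 3 has hydrogen in place of hydroxy on a saturated chain carbon bound to two saturated chain carbons relative to compound 2. Among the measured compounds shown here, no measured step isolates this change, so the only guide to size is the gap between the two numbers. A modest move toward a lower number is expected, an estimated 1.8-fold lower number from compound 2 to compound 3 (0.27 log units; within the scatter) in size. For compound 3 the estimated value is 26000 nM with an expected range of 10000 nM to 60000 nM in this assay once measured.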

Compound 3, half-maximal inhibitory concentration: 9000 nM
The estimate for compound 3 lay 2.9-fold (0.46 log units) above the measured number, and the stated range ends above it.
By their numbers in this assay, from the lowest: compound 3; then compound 1; then compound 2.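

In this assay, hydrogen in place of hydroxy on a saturated chain carbon bound to two saturated chain carbons gives a 5.3-fold lower number from compound 2 to compound 3 (0.73 log units; beyond the scatter), so the hydroxy is not required for activity on this read-out. Configuration alone also moves the number, with a 2.3-fold lower number from compound 1 to compound 3 (0.36 log units; beyond the scatter), and this reading rests on one fact: the fact that compounds 1 and 3 differ only in the configuration as drawn.

Which of the two inverted stereocentres carries that gap stays open. Also open, going by these compounds, is whether an amine or a carboxylic acid on that chain carbon would give a number nearer that of compound 3 or that of compound 2.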